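A few compounds are considered here, and "the series" means these few. Any claim that something is new, unique, unknown or untested is made for them only; others in the source may bear on it.

Compound 3 `COc1ccc(N2CCN(S(=O)(=O)c3cccc(/C=C/C(=O)NO)c3)CC2)cc1` gives 107 nM in an assay for inhibition of protein deacetylase HDAC6 (Homo sapiens), read by fluorescence, with a stated time of 3 h (on this read-out lower numbers stand for an effect already at smaller amounts and higher numbers for an effect only at larger amounts of compound), and stands second highest of the three numbers shown, though both its gaps lie within the scatter: compound 2 `O=C(/C=C/c1nc2ccccc2o1)NO` gives 68 nM and compound 1 `O=C(/C=C/c1cccc(S(=O)(=O)N2CCN(c3ccccn3)CC2)c1)NO` gives 179 nM. Going by the values given here, the only measured step at the ring nitrogen, a 1.7-fold lower number from compound 1 to compound 3 (0.22 log units; within the scatter), stayed within the scatter. Compound 4 `COc1ccccc1N1CCN(S(=O)(=O)c2cccc(/C=C/C(=O)NO)c2)CC1` differs from compound 3 by 2-methoxyphenyl in place of 4-methoxyphenyl on an amine nitrogen in a ring. Among the compounds with values here, no measured step bears on which methoxyphenyl sits on that nitrogen; the one step at this place, a 1.7-fold lower number from compound 1 to compound 3 (0.22 log units; within the scatter), was within the scatter, so the account expects no step beyond the scatter in this assay, a 1.1-fold higher number from compound 3 to compound 4 (0.05 log units; within the scatter). Compound 4 is accordingly estimated at 120 nM, expected between 55 nM and 260 nM.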

Compound 4, concentration for half-maximal effect: 305 nM
Compound 4: middle estimate off by 2.5-fold (0.41 log units), on the low side, and the stated range ends below it.
By their numbers in this assay, from the lowest: compounds 2, 3, 1 and 4 (each within the scatter of the next, the first and the last beyond it).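

In this assay, going by these compounds alone, the exchange of 4-methoxyphenyl for 2-methoxyphenyl on the amine nitrogen in the ring gives the first step at this place beyond the scatter, a 2.9-fold higher number from compound 3 to compound 4 (0.45 log units; beyond the scatter), although the two groups have the same atoms. Yet a 1.7-fold higher number from compound 1 to compound 4 (0.23 log units; within the scatter) stays within the scatter, so 2-methoxyphenyl and pyridin-2-yl are not told apart here. Nothing shown explains the step. The compounds shown leave open where 3-methoxyphenyl would fall, and whether 2-methylphenyl or 2-chlorophenyl on that nitrogen would give a similar step.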